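The compounds below may be only part of what the source reports. "The series", "measured", "known", "first", "only" and "open" are said of these compounds alone.

Compound 1, `CC(C)C(=O)OC1CCC(CN2CCN(c3cc(=O)c4cc(C(F)(F)F)cc([N+](=O)[O-])c4s3)CC2)CC1`, in an ADME assay on Vero cells (Chlorocebus sabaeus) for cytotoxicity, read by MTT assay, with a stated time of 48 h; on this read-out higher numbers stand for weaker inhibition and lower numbers for stronger inhibition: the limit > 64 ug/mL 
Compound 2, `CC(C)S(=O)(=O)OC1CCC(CN2CCN(c3cc(=O)c4cc(C(F)(F)F)cc([N+](=O)[O-])c4s3)CC2)CC1`, in this assay: the limit > 64 ug/mL 
Compound 3, `O=c1cc(N2CCN(CC3CCC(NS(=O)(=O)c4ccccc4)CC3)CC2)sc2c([N+](=O)[O-])cc(C(F)(F)F)cc12`, in this assay: the limit > 64 ug/mL 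

Compound 1 stands only at a limit of the assay in this assay, so no number places it among the others. The same holds for compound 2 and for compound 3, each of which is reported only as a limit. The three measured steps are therefore not readable in size: a step that the two limits leave unreadable from compound 1 to compound 2, a step that the two limits leave unreadable from compound 1 to compound 3 and a step that the two limits leave unreadable from compound 2 to compound 3. All that can be said is the limit of > 64 ug/mL in this assay, at which 3 of the 3 values shown sit.

Compound 4, `COc1cccc(C(=O)OC2CCC(CN3CCN(c4cc(=O)c5cc(C(F)(F)F)cc([N+](=O)[O-])c5s4)CC3)CC2)c1`, differs from compound 1 in one place: 3-methoxyphenyl in place of isopropyl on a carbonyl carbon. Among the compounds with values here, none of the measured steps changes the group on the carbonyl carbon, and the two steps that leave compound 1 touch the whole (isopropylcarbonyl)oxy group rather than its isopropyl part, so none of them bears directly on this change. With every value shown sitting at the limit, no step beyond the scatter in either direction is expected; the step that the limit leaves unreadable from compound 1 to compound 4 is expected to be no more than a change that the limits again leave unreadable. Compound 4 is therefore estimated at 90 ug/mL in this assay, within 40 ug/mL to 250 ug/mL, and most likely reported as a limit once more.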

Compound 4, half-maximal inhibitory concentration: > 64 ug/mL
Compound 4 gave a limit, no number (the forecaster's own chance of this, stated with the estimate: 80%); the middle value is on the limit's open side.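

Compound 4 is reported only as a limit, so its steps from compound 1, compound 2 and compound 3 cannot be read in size, and the four compounds cannot be ranked: the limit of > 64 ug/mL in this assay, at which 4 of the 4 values shown sit. The compounds shown leave open at what concentration any of them reaches half-maximal inhibition in this assay, and whether changing the group on the carbonyl carbon alters it.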